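Replacing the aryl group of compound 1

This account rests on a few compounds, and the source may have more. Where it says the series, first, only, none or still open, it means among the compounds named here.

In a functional assay on HCT-116 cells (Homo sapiens) for inhibition, read by MTT assay, with a stated time of 72 h (a lower number here means a stronger inhibitor, a higher number a weaker inhibitor), the measured compounds stand as follows.
compound 1 `COc1cc2c(Oc3ccc(NC(=O)c4nn(-c5ccc(F)c(Cl)c5)cc(C)c4=O)cc3)ccnc2cc1OCCCCCCC(=O)NO` gives 370 nM
compound 2 `COc1cc2c(Oc3ccc(NC(=O)c4nn(-c5ccccc5)ccc4=O)cc3)ccnc2cc1OCCCC(=O)NO` gives 940 nM
compound 3 `COc1cc2c(Oc3ccc(NC(=O)c4nn(-c5ccccc5F)cc(C)c4=O)cc3)ccnc2cc1OCCCC(=O)NO` gives 950 nM

Compound 1 holds the lowest number of the three. Compound 2 and compound 3 both stand above it by more than the scatter, and their two values lie within the scatter of each other. Among the compounds with values here, no two measured compounds differ in one place only, so the data hold no direct measure of a change on the aromatic nitrogen.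

Compound 4 `COc1cc2c(Oc3ccc(NC(=O)c4nn(-c5ccccc5C)cc(C)c4=O)cc3)ccnc2cc1OCCCCCCC(=O)NO` keeps the rest of compound 1 and carries 2-methylphenyl in place of 3-chloro-4-fluorophenyl on an aromatic nitrogen here. Compound 1 at 370 nM is the closest measured neighbour of compound 4 and anchors the expectation. Within the data shown here, with no single-place step to lean on, the range is kept wide enough to take in compound 3 at 950 nM as well. In this assay the expected step is a 1.4-fold higher number from compound 1 to compound 4 (0.13 log units; within the scatter), a small rise in the number that would stay within the scatter. For compound 4 the estimate is 500 nM, with an expected range from 200 nM to 1300 nM.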

Compound 4, half-maximal inhibitory concentration: 660 nM
Beside the measured number, compound 4's estimate is 1.3-fold (0.12 log units) below it; measured number inside the range.
By their numbers in this assay, from the lowest: compounds 1, 4, 2 and 3 (each within the scatter of the next, the first and the last beyond it).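

In this assay, 2-methylphenyl in place of 3-chloro-4-fluorophenyl on the aromatic nitrogen gives a 1.8-fold higher number from compound 1 to compound 4 (0.25 log units; within the scatter), the first direct measure of a change at this position, and compound 1 and compound 4 cannot be told apart in this read-out. For this one pair, the aryl group can lose both its chlorine and its fluorine and take a methyl group instead, with the ring count and the absence of hydrogen-bond donors and acceptors unchanged, and the step stays within the scatter. Nothing measured on these compounds accounts for this result or shows what the aryl group contributes in the cells.

As far as these compounds go, one step between two substituted phenyl groups does not define the tolerance of the position, so it remains open whether a pyridyl ring, a benzyl group, a plain methyl group or a phenyl ring bearing an amine or a carboxylic acid would also stay within the scatter of compound 1. From the compounds shown here alone, it also remains open whether a change of aryl group on the chain carried by compound 3 would give a step of similar size.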